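Trifluoromethylphenyl Exchanged for Difluorophenyl on the Chain

The compounds below may be only part of what the source reports. "The series", "measured", "known", "first", "only" and "open" are said of these compounds alone.

Three compounds share one core and differ only in the aryl group attached to the double-bonded chain. In a functional assay on COLO 205 cells (Homo sapiens) for cytotoxicity, read by MTT assay, with a stated time of 72 h (a lower number here means a stronger inhibitor, a higher number a weaker inhibitor), compound 1 `COc1ccc(/C=C/C(=O)Nc2cc(C(=O)c3cc(OC)c(OC)c(OC)c3)ccc2OC)cc1` gives 10900 nM. Compound 2 `C#CCOc1cccc(/C=C/C(=O)Nc2cc(C(=O)c3cc(OC)c(OC)c(OC)c3)ccc2OC)c1` gives 13400 nM. Compound 3 `COc1ccc(C(=O)c2cc(OC)c(OC)c(OC)c2)cc1NC(=O)/C=C/c1ccc(C(F)(F)F)cc1` gives 2600 nM, the lowest of the three numbers. The step of a 1.2-fold higher number from compound 1 to compound 2 (0.09 log units; within the scatter) stays within the scatter, whereas a 4.2-fold lower number from compound 1 to compound 3 (0.62 log units; beyond the scatter) and a 5.2-fold lower number from compound 2 to compound 3 (0.71 log units; beyond the scatter) both lie beyond it, each modest in size. Compound 4 `COc1ccc(C(=O)c2cc(OC)c(OC)c(OC)c2)cc1NC(=O)/C=C/c1ccc(F)c(F)c1` differs from compound 3 in one place: 3,4-difluorophenyl in place of 4-(trifluoromethyl)phenyl on a double-bonded chain carbon bound to a double-bonded chain carbon. The two steps that bear on this change both exchanged the aryl group on the double-bonded chain carbon and both reached compound 3 from weaker numbers. Among the compounds with values here, no measured step removes the trifluoromethyl itself, so the direction of this change is uncertain, and an estimate is placed between compound 3 and the other two compounds. Compound 4 is therefore expected to give about 4500 nM, with a range from 1800 nM to 11000 nM. This estimate corresponds to an expected step of a 1.7-fold higher number from compound 3 to compound 4 (0.24 log units; within the scatter).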

Compound 4, half-maximal inhibitory concentration: 6020 nM
Beside the measured number, compound 4's estimate is 1.3-fold (0.13 log units) below it; the measured number falls inside the stated range.
By their numbers in this assay, from the lowest: compound 3; then compounds 4, 1 and 2 (each within the scatter of the next, the first and the last beyond it).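

In this assay, within the data shown here, the change from 4-(trifluoromethyl)phenyl to 3,4-difluorophenyl gives a 2.3-fold higher number from compound 3 to compound 4 (0.36 log units; beyond the scatter) and is the first step here that leaves compound 3 rather than reaching it. Set against the other aryl groups on this chain carbon, the same 3,4-difluorophenyl group gives a 2.2-fold lower number from compound 2 to compound 4 (0.35 log units; beyond the scatter) but only a 1.8-fold lower number from compound 1 to compound 4 (0.26 log units; within the scatter) and so stands clear of one neighbour and not of the other. Of the four aryl groups, only the 4-(trifluoromethyl)phenyl of compound 3 now stands beyond the scatter from all the rest, so two fluorine-bearing aryl groups do not read alike at this position.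

On these data alone, how an aryl group bearing a nitrile or an amine would read on this chain carbon remains open. Nothing available here explains the differences among these aryl groups.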